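The source may report more compounds than this note shows. Statements on the series, on what has been measured and on what is new or still open speak of the compounds shown alone.

The study concerns three compounds measured in a functional assay on BMDM cells (Mus musculus, strain C57BL/6) for inhibition, with a stated time of 2 days (a lower number here means a stronger inhibitor, a higher number a weaker inhibitor), and a fourth, compound 4, that awaits measurement. Compound 1 `C#Cc1ccc(-c2cn(CC(=O)Nc3cc(C)on3)nn2)cc1` gives in this assay only a limit of the assay, > 30000 nM, and not a number. Compound 2 `O=C(Cn1cc(-c2ccccc2Cl)nn1)Nc1nc2ccccc2s1` likewise returns in this assay only a limit, > 30000 nM. Compound 3 `COc1cccc(-c2cn(-c3ccc(C(F)(F)F)cc3)nc2C(=O)N2CCN(c3ncccn3)CC2)c1` stands in the same position: in this assay compound 3 gives a limit, > 30000 nM, so no number for it is known. The whole measured record is the limit of > 30000 nM in this assay, at which 3 of the 3 values shown sit, and nothing in it separates one compound from another. Compound 4 `COc1cccc(-c2cn(-c3ccc(C(F)(F)F)cc3)nc2C(=O)N2CCc3ccccc3C2)c1` differs from compound 3 in one place (1,2,3,4-tetrahydroisoquinolin-2-yl in place of 4-(pyrimidin-2-yl)piperazin-1-yl on a carbonyl carbon). For the measured compounds named here, no step between measured compounds exists to guide the expectation, and with every value resting at the limit there is no sign in this assay of a direction either way. The step is expected to be a number no higher from compound 3 to compound 4 (the limit leaves the size open), nothing beyond the scatter. Compound 4 is therefore estimated at 30000 nM, with a range from 8000 nM to 100000 nM, most likely again reported only as a limit.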

Compound 4, half-maximal inhibitory concentration: > 30000 nM
Compound 4 was reported as a limit; the forecaster's own chance of this, stated with the estimate: 75%; the middle value lies on the limit itself.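

Compound 3 and compound 4 both give only a limit in this assay, and no step between them can be read: the limit of > 30000 nM in this assay, at which 4 of the 4 values shown sit.

The compounds shown leave open how 1,2,3,4-tetrahydroisoquinolin-2-yl and 4-(pyrimidin-2-yl)piperazin-1-yl compare, and what structural change would yield a measurable number.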